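The source may hold more compounds than are shown below. What is called first, only, known or untested is meant among the compounds shown, and "the series" means these compounds.

- Compound 1 `CC1(C)[C@H]2CC[C@]1(C)N(Cc1cn(-c3ccc(F)cc3)nn1)C(=O)C2`: 230 nM
- Compound 2 `CC1(C)[C@H]2CC[C@]1(C)N(Cc1cn(-c3ccccc3O)nn1)C(=O)C2`: 230 nM

For the measured compounds named here, in a functional assay on A549 cells (Homo sapiens) for inhibition, read by MTT assay, with a stated time of 24 h (on this read-out lower numbers stand for stronger inhibition and higher numbers for weaker inhibition), compound 2 gives 230 nM, level with compound 1, the only other compound measured so far. Compound 3 `Cc1ccccc1-n1cc(CN2C(=O)C[C@@H]3CC[C@@]2(C)C3(C)C)nn1` is not yet measured. It keeps the shared core and turns 2-hydroxyphenyl into 2-methylphenyl, with methyl in place of hydroxy on an aromatic carbon, ortho to a large group: methyl in place of hydroxy on an aromatic carbon.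

Going by the values given here, one measured step bears on this change. The step of no change at the digits printed from compound 1 to compound 2 (within the scatter) also swapped the group on the aromatic nitrogen, and it stayed within the scatter. Among the compounds with values here, on that single step, no shift beyond the scatter is expected in this assay, though one step is thin evidence and no measured compound carries this methyl. The estimated change is no change at the digits printed from compound 2 to compound 3 (within the scatter). For compound 3 the expected value is 230 nM, with an estimated range of 100 nM to 550 nM.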

Compound 3, half-maximal inhibitory concentration: 90 nM
Compound 3: middle estimate off by 2.6-fold (0.41 log units), on the high side, and the stated range ends above it.
By their numbers in this assay, from the lowest: compound 3; then compounds 1 and 2 (each within the scatter of the next).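

In this assay, the swap of hydroxy for methyl gives a 2.6-fold lower number from compound 2 to compound 3 (0.41 log units; beyond the scatter) and so shows that this position does respond to what is placed on it, which the level pair of compound 1 and compound 2 could not show. The change to 2-methylphenyl from the other aryl group gives a 2.6-fold lower number from compound 1 to compound 3 (0.41 log units; beyond the scatter) and so sets 2-methylphenyl apart from both 4-fluorophenyl and 2-hydroxyphenyl. Nothing measured here explains why the methyl goes with the lower number.

The compounds shown leave open whether an ethyl, a methoxy or an amine in the same place would follow the methyl or the hydroxy. They also leave open whether a plain phenyl, with no added group at all, would sit with compound 3 or with compound 2.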